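From 3-methoxyphenyl to 1H-indol-3-yl on the shared core

This account rests on a few compounds, and the source may have more. Where it says the series, first, only, none or still open, it means among the compounds named here.

In a functional assay on SMMC-7721 cells (Homo sapiens) for cytotoxicity, read by MTT assay, with a stated time of 72 h (on this read-out lower numbers stand for stronger inhibition and higher numbers for weaker inhibition), compound 1 `O=C1C(=Cc2ccc(Cl)cc2)C(=O)N(c2ccc(Cl)cc2)N1c1ccc(Cl)cc1` gives 30900 nM. Compound 3 `COc1cccc(C=C2C(=O)N(c3ccc(Cl)cc3)N(c3ccc(Cl)cc3)C2=O)c1` gives 30200 nM, level with the former: a 1.0-fold lower number from compound 1 to compound 3 (0.01 log units; within the scatter). Compound 2 `COc1ccc(C=C2C(=O)N(c3ccc(Cl)cc3)N(c3ccc(Cl)cc3)C2=O)cc1` reaches only a limit of the assay, > 128000 nM. Compound 4 `O=C1C(=Cc2c[nH]c3ccccc23)C(=O)N(c2ccc(Cl)cc2)N1c1ccc(Cl)cc1` differs from compound 3 by 1H-indol-3-yl in place of 3-methoxyphenyl on a double-bonded chain carbon bound to a double-bonded ring carbon, with 1H-indol-3-yl in place of 3-methoxyphenyl on a double-bonded chain carbon bound to a double-bonded ring carbon. Two measured exchanges at this place bear on it. One stays within the scatter, a 1.0-fold lower number from compound 1 to compound 3 (0.01 log units; within the scatter), while the other is at least modest, an at least 4.2-fold lower number from compound 2 to compound 3 (0.62 log units; beyond the scatter). As far as these compounds go, neither involves 1H-indol-3-yl, so the direction remains open, and the expected change is a 1.2-fold lower number from compound 3 to compound 4 (0.08 log units; within the scatter), with no shift beyond the scatter anticipated. For compound 4 the estimate is 25000 nM, with an expected range from 6000 nM to 100000 nM.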

Compound 4, half-maximal inhibitory concentration: 19600 nM
Estimate against measurement, compound 4: 1.3-fold (0.11 log units) above; the measured number falls inside the stated range.
By their numbers in this assay, from the lowest: compounds 4, 3 and 1 (each within the scatter of the next). At a limit, above all of these: compound 2.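

In this assay, the place on the double-bonded chain carbon takes 1H-indol-3-yl, which brings a five-membered aromatic ring and a hydrogen-bond donor, with no shift beyond the scatter: a 1.5-fold lower number from compound 3 to compound 4 (0.19 log units; within the scatter), and a 1.6-fold lower number from compound 1 to compound 4 (0.20 log units; within the scatter). Only against compound 2 does the exchange exceed the scatter: an at least 6.5-fold lower number from compound 2 to compound 4 (0.81 log units; beyond the scatter). That step rests on a limit, not a number: the limit of > 128000 nM in this assay, at which 1 of the 4 values shown sits. The compounds shown leave open what a phenyl carrying a carboxylic acid or an amine would give at this place. They also leave open how 1H-indol-3-yl with a methyl on its ring nitrogen would read.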